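Chloro to fluoro in a closely grouped series

The source may report more compounds than this note shows. Statements on the series, on what has been measured and on what is new or still open speak of the compounds shown alone.

Of the compounds shown here, three sharing one core have been measured in a functional assay on the whole organism for inhibition, with Rattus norvegicus as the target, with a stated time of 1 h; on this read-out higher numbers stand for an effect only at larger amounts of compound and lower numbers for an effect already at smaller amounts. There, compound 1 `CC1(C)OC(/C=C/c2ccc(C#N)cc2)=CC1=O` gives 12 mg/kg, compound 2 `CC1(C)OC(/C=C/c2ccc(F)cc2F)=CC1=O` gives 11 mg/kg, and compound 3 `CC1(C)OC(/C=C/c2ccc(Cl)cc2)=CC1=O` gives 10.3 mg/kg. Compound 3 therefore stands level with the other two, its value lying within the usual scatter of both.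

Compound 4 `CC1(C)OC(/C=C/c2ccc(F)cc2)=CC1=O` has not yet been measured. It carries fluoro in place of chloro on an aromatic carbon, para to a large group: fluoro in place of chloro on an aromatic carbon. Within the data shown here, no measured pair shows this exchange directly. The closest evidence is a 1.2-fold lower number from compound 1 to compound 3 (0.07 log units; within the scatter), which replaces cyano with chloro on an aromatic carbon and stays within the scatter. Compound 2 also carries fluoro on its aromatic ring, and its value of 11 mg/kg falls in the same narrow band. Among the measured compounds shown here, with only three values, this is thin support, but nothing in them points to a step beyond the scatter for the new exchange.

The estimated change is a 1.1-fold higher number from compound 3 to compound 4 (0.03 log units; within the scatter), which is expected to remain within the scatter. In this assay, the value expected for compound 4 is 11 mg/kg, with an estimated range of 7 mg/kg to 17 mg/kg.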

Compound 4, dose for half-maximal effect: 11 mg/kg
For compound 4 middle estimate and measured number coincide at the digits printed; the measured number falls inside the stated range.
By their numbers in this assay, from the lowest: compounds 3, 2, 4 and 1 (each within the scatter of the next).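

In this assay, the exchange of chloro for fluoro on an aromatic carbon, para to a large group, can now be read directly, as a 1.1-fold higher number from compound 3 to compound 4 (0.03 log units; within the scatter), and the comparison with the nitrile-bearing compound gives a 1.1-fold lower number from compound 1 to compound 4 (0.04 log units; within the scatter) for fluoro in place of cyano. Removing the extra fluoro from the ring, with hydrogen in its place on an aromatic carbon, gives no change at the digits printed from compound 2 to compound 4 (within the scatter), so all three steps to the new compound stay within the scatter, and none of the four compounds goes against this flat picture. No accompanying measurement offers an explanation for why these exchanges leave the number so little moved.

The compounds shown span only chloro, fluoro, cyano and a second fluoro on the ring, so it remains open whether an amine, a carboxylic acid or a longer chain at this place would also stay within the scatter. They also leave open whether a hydrogen at this place, with no halogen or nitrile on the ring at all, would give a number in the same narrow band.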